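Adding a Second Chloro to the Aryl Ring of Compound 2

This account rests on a few compounds, and the source may have more. Where it says the series, first, only, none or still open, it means among the compounds named here.

Compound 2 `CCCC[C@H](CCn1cncn1)c1ccc(Cl)cc1` was tested in an ADME assay on RD cells (Homo sapiens) for cytotoxicity, read by MTT assay, with a stated time of 3 days (a higher number here means that more compound is tolerated, a lower number that less compound is tolerated), where compound 2 gives 20.3 ug/mL. Among the two compounds measured so far, compound 2 holds the lowest number; its nearest neighbour is compound 1 `CCCC[C@H](CCn1cncn1)c1ccccc1`, which in this assay gives 48.3 ug/mL. For the measured compounds named here, the only measured step between them is a 2.4-fold lower number from compound 1 to compound 2 (0.38 log units; beyond the scatter), a chloro in place of hydrogen on an aromatic carbon.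

Compound 3 `CCCC[C@H](CCn1cncn1)c1ccc(Cl)cc1Cl` has not yet been measured. It differs from compound 2 by chloro in place of hydrogen on an aromatic carbon, on an aromatic carbon of a six-membered aromatic ring of carbon only. Going by the values given here, the single step that bears on this change, a 2.4-fold lower number from compound 1 to compound 2 (0.38 log units; beyond the scatter), lowered the number modestly, so a further modest lowering in this assay is expected, with limited confidence given one precedent. The expected step is a 1.7-fold lower number from compound 2 to compound 3 (0.23 log units; within the scatter). Compound 3 is therefore estimated at 12 ug/mL, within a range from 6 ug/mL to 25 ug/mL.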

Compound 3, half-maximal cytotoxic concentration: 10.1 ug/mL
The estimate for compound 3 lay 1.2-fold (0.07 log units) above the measured number; low and high end bracket the measured number.
By their numbers in this assay, from the lowest: compounds 3 and 2 (each within the scatter of the next); then compound 1.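

In this assay the chloro that enters ortho to a large group and meta to a chloro group gives a 2.0-fold lower number from compound 2 to compound 3 (0.30 log units; within the scatter), a step that does not separate the pair. Where a 2.4-fold lower number from compound 1 to compound 2 (0.38 log units; beyond the scatter) stood clear of the scatter, the same change at this position shows no resolved effect, so one further chloro on this ring does not by itself give a second clear step. Nothing measured here offers a reason for this result.

The compounds shown leave open whether a different group at this position, such as a methyl, a methoxy or an amine, would stand apart from compound 2 in this assay. They also leave open whether a second chloro on another carbon of the same ring would give a step beyond the scatter.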